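From chloro to cyclopropyl on one aromatic carbon

A few compounds are considered here, and "the series" means these few. Any claim that something is new, unique, unknown or untested is made for them only; others in the source may bear on it.

In a physicochemical assay for solubility, at pH 6.5 (a higher number here means a more soluble compound, a lower number a less soluble compound), compound 1 (`Cn1ncc2c(NC3(c4ccc(C(F)(F)F)cc4)CC3)nc(O)nc21`) gives 175000 nM and compound 2 (`Cn1ncc2c(NC3(c4ccc(C(F)(F)F)cc4)CC3)nc(Cl)nc21`) gives 156000 nM as its reading, so compound 2 stands level with compound 1 within the scatter. Compound 3 (`Cn1ncc2c(NC3(c4ccc(C(F)(F)F)cc4)CC3)nc(C3CC3)nc21`) has cyclopropyl in place of chloro on an aromatic carbon is the whole change. Going by the values given here, the only measured step at this carbon, a 1.1-fold lower number from compound 1 to compound 2 (0.05 log units; within the scatter) for chloro in place of hydroxy, stayed within the scatter, so no step beyond the scatter is expected in this assay and any shift should be a slightly lower number. The estimated step is a 1.3-fold lower number from compound 2 to compound 3 (0.11 log units; within the scatter) and stays within the scatter. For compound 3 the estimate is 120000 nM and the expected range runs from 40000 nM to 220000 nM in this measurement.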

Compound 3, solubility: 125000 nM
Compound 3: middle estimate off by 1.0-fold (0.02 log units), on the low side, within the range that was stated.
By their numbers in this assay, from the lowest: compounds 3, 2 and 1 (each within the scatter of the next).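

In this assay, cyclopropyl on this aromatic carbon reads level with chloro (a 1.2-fold lower number from compound 2 to compound 3 (0.10 log units; within the scatter)) and with hydroxy (a 1.4-fold lower number from compound 1 to compound 3 (0.15 log units; within the scatter)). Going by these compounds alone, compounds 1, 2 and 3 therefore show that even a change to a group with a three-membered ring leaves the reading within the scatter at this position, which the single earlier step could not show. No measurement is available here that would explain this.

On these data alone, whether an amine, a carboxylic acid or a longer chain on this same carbon would give a step beyond the scatter remains open. So does whether cyclopropyl would behave the same way elsewhere on the shared core.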